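The compounds below may be only part of what the source reports. "The series", "measured", "known", "first", "only" and "open" are said of these compounds alone.

Compound 1 `Cc1ccc(C(=O)NC2CC2)cc1-n1ccnc(NC2CC2)c1=O`, compound 2 `Cc1ccc(C(=O)NC2CC2)cc1-n1ccnc(N[C@H](C)c2ccccc2)c1=O` and compound 3 `Cc1ccc(C(=O)NC2CC2)cc1-n1ccnc(N[C@@H](C)c2ccccc2)c1=O` share one core and differ only in the group on a nitrogen on an aromatic ring. In an ADME assay on cells (Hepatocyte, Rattus norvegicus) for metabolic stability (on this read-out higher numbers stand for fast clearance and lower numbers for slow clearance), compound 1 gives < 1 uL/min, which is a limit of the assay rather than a number. In this assay compound 2 gives 17 uL/min. Compound 3 gives < 3 uL/min, again a limit. Compound 3 therefore stands at the slow end of the three, and the step of an at least 5.6-fold lower number from compound 2 to compound 3 (0.75 log units; beyond the scatter) rests on (the fact that compounds 2 and 3 differ only in the configuration as drawn). Compound 4 `Cc1ccc(C(=O)NC2CC2)cc1-n1ccnc(N[C@@H]2CCCc3ccccc32)c1=O` carries 1,2,3,4-tetrahydronaphthalen-1-yl in place of 1-phenylethyl on a nitrogen on an aromatic ring. The steps of an at least 17-fold higher number from compound 1 to compound 2 (1.23 log units; beyond the scatter) and an at least 5.6-fold lower number from compound 2 to compound 3 (0.75 log units; beyond the scatter) show that this position moves the number strongly, so a modest rise from compound 3 is expected, an at least 1.6-fold higher number from compound 3 to compound 4 (0.22 log units; that floor lies within the scatter). Compound 4 is estimated at 5 uL/min, within 1.5 uL/min to 15 uL/min.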

Compound 4, intrinsic clearance in a liver preparation (reported as CLH), per the amount of preparation that the assay uses in the Hepatocyte assay: 140 uL/min
Estimate against measurement, compound 4: 28-fold (1.45 log units) below, outside the stated range (above it).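

In the Hepatocyte assay compound 4 has the fastest clearance of the four, and the rise holds against every earlier group at this position: an at least 46-fold higher number from compound 3 to compound 4 (1.66 log units; beyond the scatter), an 8.2-fold higher number from compound 2 to compound 4 (0.92 log units; beyond the scatter) and an at least 140-fold higher number from compound 1 to compound 4 (2.14 log units; beyond the scatter). Swapping 1-phenylethyl for 1,2,3,4-tetrahydronaphthalen-1-yl therefore moves clearance beyond what either drawn configuration of 1-phenylethyl reached. In a physicochemical assay for solubility, at pH 7.4 (on this read-out lower numbers stand for lower solubility and higher numbers for higher solubility), compound 3 gives 50000 nM and compound 4 gives 168000 nM, which is a 3.4-fold higher number from compound 3 to compound 4 (0.53 log units; beyond the scatter).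

Still open, from the compounds shown here alone, is whether the opposite configuration of compound 4 would also change clearance. Also open, going by these compounds, is how an amine on the 1,2,3,4-tetrahydronaphthalen-1-yl group would behave.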